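The source may hold more compounds than are shown below. What is called first, only, known or untested is meant among the compounds shown, and "the series" means these compounds.

Compound 1, `C/C=C/C=C/C(=O)C[C@H](CCO)OC`, gives 30000 nM in a functional assay on MDA-MB-231 cells (Homo sapiens) for inhibition; a lower number here means a stronger inhibitor of growth, a higher number a weaker inhibitor of growth. For the measured compounds named here, that is the lowest of the two numbers measured so far, but only just: compound 2, `C/C=C/CCC(=O)C[C@@H](O)CCO`, gives 54000 nM in this assay, and the two values lie within the scatter of each other, so neither can be called the stronger inhibitor on these data. Compound 3, `C/C=C/C=C/C(=O)C[C@@H](O)CCO`, is not yet measured. It differs from compound 1 in one place: hydrogen in place of methyl on an oxygen on a saturated carbon. Going by the values given here, no step of this kind between two measured compounds is available, so the size and direction of the change it brings can only be guessed. Compound 2 carries the same hydroxy group and gives a value close to that of compound 1, which offers no sign of a large shift in either direction. Compound 3 is therefore expected to land near compound 1, with a step of a 1.2-fold higher number from compound 1 to compound 3 (0.07 log units; within the scatter) that stays within the scatter. The estimate for compound 3 in this assay is 35000 nM, with a range from 15000 nM to 80000 nM.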

Compound 3, concentration for 50% growth inhibition: 54000 nM
Beside the measured number, compound 3's estimate is 1.5-fold (0.19 log units) below it; measured number inside the range.
By their numbers in this assay, from the lowest: compounds 1, 2 and 3 (each within the scatter of the next).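

The direct step at this position, from methoxy to hydroxy on the saturated carbon, gives a 1.8-fold higher number from compound 1 to compound 3 (0.26 log units; within the scatter) in this assay and replaces the earlier guess with a measured pair. On this core, therefore, the methyl on that oxygen can be exchanged for hydrogen without a difference that this assay can separate from its scatter. Nothing measured alongside these values bears on why the two compounds read alike.

The compounds shown cover only methoxy and hydroxy at this place, so it remains open whether an ethoxy group, a longer chain on the oxygen, or an amine or a carboxylic acid in place of the hydroxy would also leave the number within the scatter. On these data alone, whether any change here can move growth inhibition at all also remains open.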